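A Methyl Added to the Benzylic Carbon of Compound 1

This account rests on a few compounds, and the source may have more. Where it says the series, first, only, none or still open, it means among the compounds named here.

Compound 1, with the structure `CCC(COc1cccc(Cl)c1)OC(=O)NCc1ccccc1`, is measured in an assay for inhibition of zeta-carotene desaturase, chloroplastic/chromoplastic (Capsicum annuum), using a Dixon plot, with a stated time of 8 h; a higher number here means a weaker inhibitor, a lower number a stronger inhibitor. In this assay compound 1 gives only a limit, > 100000 nM. Compound 2, `CCC(COc1ccc(Cl)cc1)OC(=O)NCc1ccccc1`, carries 4-chlorophenyl in place of 3-chlorophenyl on an oxygen on a saturated carbon; in this assay compound 2 also gives only a limit, > 100000 nM. Compound 3, `CCC(COc1cccc(C)c1)OC(=O)NCc1ccccc1`, carries methyl in place of chloro on an aromatic carbon; in this assay compound 3 likewise gives only a limit, > 100000 nM. The steps among these three cannot be sized: a step that the two limits leave unreadable from compound 1 to compound 2, a step that the two limits leave unreadable from compound 1 to compound 3 and a step that the two limits leave unreadable from compound 2 to compound 3, all unreadable because of the limit of > 100000 nM in this assay, at which 3 of the 3 values shown sit.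

Compound 4, `CCC(COc1cccc(Cl)c1)OC(=O)N[C@H](C)c1ccccc1`, differs from compound 1 by methyl in place of hydrogen on a saturated chain carbon bound to an amide-type nitrogen and an aromatic carbon. Among the compounds with values here, none of the measured steps touches that carbon, and none has a readable size, so they give no direction and no magnitude for this change. Compound 4 is therefore expected to remain at the limit of this assay, with the step expected in this assay being a step that the limit leaves unreadable from compound 1 to compound 4. The estimate for compound 4 in this assay is 150000 nM, expected to lie between 50000 nM and 500000 nM.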

Compound 4, half-maximal inhibitory concentration: > 100000 nM
Compound 4 gave a limit, no number (the forecaster's own chance of this, stated with the estimate: 80%); the middle value lies beyond the limit too.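

In this assay compound 4 gives > 100000 nM, which is a limit and not a number, so the change from benzyl to 1-phenylethyl between compound 1 and compound 4 cannot be sized, because the values share one limit: the limit of > 100000 nM in this assay, at which 4 of the 4 values shown sit. The compounds shown leave open whether any of these changes affects inhibition at all, as none gives a number to compare.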